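Swapping Chloro for Hydroxy on Compound 2

A few compounds are considered here, and "the series" means these few. Any claim that something is new, unique, unknown or untested is made for them only; others in the source may bear on it.

In a functional assay on MDA-MB-231 cells (Homo sapiens) for inhibition, read by MTT assay (on this read-out lower numbers stand for stronger inhibition and higher numbers for weaker inhibition), compound 1 (`N#Cc1cccc(-c2cn(CCCCCCn3cccc(/C=C/C(=O)NO)c3=O)nn2)c1`) gives 600 nM and compound 2 (`O=C(CCC(=O)Nc1nnc(-c2ccc(Cl)cc2)s1)NO`) gives 14700 nM as the higher of the two numbers, which marks the weaker inhibition. Compound 3 (`O=C(CCC(=O)Nc1nnc(-c2ccc(O)cc2)s1)NO`) differs from compound 2 by hydroxy in place of chloro on an aromatic carbon with hydroxy in place of chloro on an aromatic carbon, para to a large group. Within the data shown here, no measured pair shows this change, so the expectation rests on the structures alone. In this assay the estimated change is a 1.4-fold higher number from compound 2 to compound 3 (0.13 log units; within the scatter) toward weaker inhibition, a step expected to stay within the scatter. Compound 3 is expected at 20000 nM (estimated range 7000 nM to 60000 nM).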

Compound 3, half-maximal inhibitory concentration: 14700 nM
Beside the measured number, compound 3's estimate is 1.4-fold (0.13 log units) above it, and the stated range covers the measured number.
By their numbers in this assay, from the lowest: compound 1; then compounds 2 and 3 (each within the scatter of the next).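

In this assay, replacing 4-chlorophenyl with 4-hydroxyphenyl gives no change at the digits printed from compound 2 to compound 3 (within the scatter), the first single-place step available in this set. At this aromatic carbon, para to a large group, a hydroxy carrying one hydrogen-bond donor and one acceptor therefore reads the same as a chloro carrying neither. No supporting data bear on why the two groups read alike.

As far as these compounds go, whether an amine or a methoxy group at this position would also read the same remains open. So does whether a longer chain elsewhere on compound 2 would move the number.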